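This account rests on a few compounds, and the source may have more. Where it says the series, first, only, none or still open, it means among the compounds named here.

Measured compounds in a functional assay on MT4 cells (Homo sapiens) for cytotoxicity; on this read-out higher numbers stand for lower toxicity in this test and lower numbers for higher toxicity in this test:

- compound 1 `CN(C)c1ncnc2c1ncn2[C@@H]1O[C@H](CO[Si](C)(C)C(C)(C)C)[C@@]2(OS(=O)(=O)C=C2N)[C@H]1O[Si](C)(C)C(C)(C)C` — 15000 nM
- compound 2 `Cn1cnc2c(ncn2[C@@H]2O[C@H](CO[Si](C)(C)C(C)(C)C)[C@@]3(OS(=O)(=O)C=C3N)[C@H]2O[Si](C)(C)C(C)(C)C)c1=O` — only a limit of the assay: > 150000 nM
- compound 3 `CC(C)(C)[Si](C)(C)OC[C@H]1O[C@@H](n2cnc3cncnc32)[C@H](O[Si](C)(C)C(C)(C)C)[C@]12OS(=O)(=O)C=C2N` — 13000 nM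

Compound 3 gives the lowest of the two numbers in this assay, but its neighbour compound 1 sits within the scatter of it (a 1.2-fold lower number from compound 1 to compound 3 (0.06 log units; within the scatter)). The third value, that of compound 2, is a limit of the assay and not a number (the limit of > 150000 nM in this assay, at which 1 of the 3 values shown sits).

Compound 4 `COc1ncnc2c1ncn2[C@@H]1O[C@H](CO[Si](C)(C)C(C)(C)C)[C@@]2(OS(=O)(=O)C=C2N)[C@H]1O[Si](C)(C)C(C)(C)C` is not yet measured. It differs from compound 3 by methoxy in place of hydrogen on an aromatic carbon.

Within the data shown here, the step that bears on this change is the one between compound 1 and compound 3, where a dimethylamino group at the same aromatic carbon is exchanged for hydrogen: a 1.2-fold lower number from compound 1 to compound 3 (0.06 log units; within the scatter). The two large steps, an at least 10-fold higher number from compound 1 to compound 2 (1.00 log units; beyond the scatter) and an at least 11-fold lower number from compound 2 to compound 3 (1.06 log units; beyond the scatter), concern the exchange of the whole fused ring system on the saturated ring carbon and do not speak to a small substituent at this aromatic carbon. A substituent at this position therefore seems to move this assay little, and for compound 4 a step of a 1.2-fold higher number from compound 3 to compound 4 (0.06 log units; within the scatter) is expected, within the scatter. Compound 4 is estimated at 15000 nM, with a range from 6000 nM to 40000 nM.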

Compound 4, half-maximal cytotoxic concentration: 21000 nM
The estimate for compound 4 lay 1.4-fold (0.15 log units) below the measured number; low and high end bracket the measured number.
By their numbers in this assay, from the lowest: compounds 3, 1 and 4 (each within the scatter of the next). At a limit, above all of these: compound 2.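

Methoxy on this aromatic carbon gives a third substituent here, and in this assay its exchange for hydrogen stays small: a 1.6-fold higher number from compound 3 to compound 4 (0.21 log units; within the scatter). Its exchange for dimethylamino is equally small: a 1.4-fold higher number from compound 1 to compound 4 (0.15 log units; within the scatter); hydrogen, dimethylamino and methoxy therefore cannot be put in any order on this read-out, and an oxygen-linked group behaves here like the nitrogen-linked one. The distance to the fused ring system of compound 2 also persists with methoxy in the series: an at least 7.1-fold lower number from compound 2 to compound 4 (0.85 log units; beyond the scatter), so among the compounds shown, only the exchange of the whole ring group on the saturated ring carbon gives a step beyond the scatter.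

The true size of that distance stays open, since the value of compound 2 is a limit of the assay and not a number: the limit of > 150000 nM in this assay, at which 1 of the 4 values shown sits. Also open is whether this position stays as quiet in this assay with a primary amine, a carboxylic acid or a longer alkoxy chain such as butoxy on this aromatic carbon, since the three groups shown cover only a narrow set.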